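Fluoro for methoxy on the shared core of compound 1

The source may hold more compounds than are shown below. What is called first, only, known or untested is meant among the compounds shown, and "the series" means these compounds.

Compound 1 `COc1ccccc1NC(=O)SC[C@H](NC(C)=O)C(=O)O` is the reference of this set. In a functional assay on OVCAR-3 cells (Homo sapiens) for cytotoxicity, read by MTT assay, with a stated time of 6 days (on this read-out higher numbers stand for weaker inhibition and lower numbers for stronger inhibition), compound 1 gives only a limit, > 200000 nM. Compound 2 `COc1ccc(OC)c(NC(=O)SC[C@H](NC(C)=O)C(=O)O)c1` carries a methoxy in place of hydrogen on an aromatic carbon; in this assay compound 2 likewise gives only a limit, > 200000 nM. The step that the two limits leave unreadable from compound 1 to compound 2 is accordingly not readable. Compound 3 `CC(=O)N[C@@H](CSC(=O)Nc1cccc2ccccc12)C(=O)O` in this assay also gives only a limit, > 200000 nM. All three thus sit together, (the limit of > 200000 nM in this assay, at which 3 of the 3 values shown sit).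

Compound 4 `CC(=O)N[C@@H](CSC(=O)Nc1ccccc1F)C(=O)O` is the unmeasured member; (fluoro in place of methoxy on an aromatic carbon). Among the compounds with values here, no measured step here separates two numbers. For compound 4 the step that the limit leaves unreadable from compound 1 to compound 4 is expected to show no direction beyond the scatter. Compound 4 is thus estimated at 250000 nM (range 100000 nM to 1000000 nM) in this assay, most likely again reported only as a limit.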

Compound 4, half-maximal inhibitory concentration: > 200000 nM
Compound 4 gave a limit, no number (the forecaster's own chance of this, stated with the estimate: 85%); the middle value lies beyond the limit too.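

Within the data shown here, compound 1 and compound 4 each give only a limit, so no step between them can be read: the limit of > 200000 nM in this assay, at which 4 of the 4 values shown sit. The compounds shown leave open whether any change on the shared core gives a readable number in this assay.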